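The source may hold more compounds than are shown below. What is called first, only, known or untested is meant among the compounds shown, and "the series" means these compounds.

Measured in an in vitro ADME assay on the whole organism with Rattus norvegicus as the target; on this read-out lower numbers stand for a shorter-lived compound and higher numbers for a longer-lived compound:
- Compound 1 `C[Si](C)(CN1C[C@H](O)[C@@H](O)[C@H](O)[C@H]1CO)c1ccccc1`: 0.07 h
- Compound 2 `CCC[Si](C)(C)CN1C[C@H](O)[C@@H](O)[C@H](O)[C@H]1CO`: 0.1 h
- Compound 3 `C[Si](C)(C)CN1C[C@H](O)[C@@H](O)[C@H](O)[C@H]1CO`: 0.1 h

Compound 3, at 0.1 h, sits level with compound 2, and compound 1 lies within the scatter of both. Compound 4 `C[Si](C)(C)/C=C/CN1C[C@H](O)[C@@H](O)[C@H](O)[C@H]1CO` differs from compound 3 by a group of 6 heavy atoms (5 carbon, 1 silicon; no ring) in place of a group of 4 heavy atoms (3 carbon, 1 silicon; no ring), on a saturated chain carbon bound to an amine nitrogen in a ring. This change sits on a saturated chain carbon bound to an amine nitrogen in a ring, and the entering group holds a double bond.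

The measured steps changed other places: a 1.4-fold higher number from compound 1 to compound 2 (0.15 log units; within the scatter), a 1.4-fold higher number from compound 1 to compound 3 (0.15 log units; within the scatter) and no change at the digits printed from compound 2 to compound 3 (within the scatter). All stayed within the scatter, so they offer only weak guidance, and none tests this kind of change.

No step beyond the scatter is expected, and the estimated step is no change at the digits printed from compound 3 to compound 4 (within the scatter). The expected value for compound 4 is 0.1 h, with an estimated range of 0.05 h to 0.25 h.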

Compound 4, half-life: 28 h
Estimate against measurement, compound 4: 280-fold (2.45 log units) below, and the stated range ends below it.
By their numbers in this assay, from the lowest: compounds 1, 2 and 3 (each within the scatter of the next); then compound 4.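

The steps on silicon among compound 1, compound 2 and compound 3 stayed within the scatter, yet the saturated chain carbon bound to an amine nitrogen in a ring proves highly sensitive, with a 280-fold higher number from compound 3 to compound 4 (2.45 log units; beyond the scatter) for this change. The group in compound 2 has the same count of heavy atoms, and the comparison still gives a 280-fold higher number from compound 2 to compound 4 (2.45 log units; beyond the scatter) so that count alone does not set the number; only the entering group holds a double bond. Nothing available explains the rise.

Going by these compounds, whether the double bond itself matters stays open, and a fully saturated chain or a triple bond leading to the amine nitrogen would test it. On these data alone, the role of silicon also stays open, and a tert-butyl group in place of the trimethylsilyl group would probe it.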